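The compounds below may be only part of what the source reports. "The series", "measured", "known", "first", "only" and "open" are said of these compounds alone.

Of the compounds shown here, two from this series have so far been measured in a functional assay on H4 cells with growth hormone secretagogue receptor type 1 (Homo sapiens) as the target, read by FLIPR; on this read-out higher numbers stand for an effect only at larger amounts of compound and lower numbers for an effect already at smaller amounts. Compound 1 `CC(C)(N)C(=O)N[C@H](COCc1ccccc1)c1nnnn1CCOC(=O)NCCO` gives 3 nM, while compound 2 `CC1(O)CCN(C(=O)OCCn2nnnc2[C@@H](COCc2ccccc2)NC(=O)C(C)(C)N)C1` gives 10.1 nM. For the measured compounds named here, compound 2 therefore stands at the higher of the two numbers, and the single step between them, a 3.4-fold higher number from compound 1 to compound 2 (0.53 log units; beyond the scatter), came from putting 3-hydroxy-3-methylpyrrolidin-1-yl in place of (2-hydroxyethyl)amino on the carbonyl carbon.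

Compound 3 `CC(C)(N)C(=O)N[C@H](COCc1ccccc1)c1nnnn1CCOC(=O)NCCCn1ccnc1` has not been measured yet. It differs from compound 2 in one place: (3-(1H-imidazol-1-yl)propyl)amino in place of 3-hydroxy-3-methylpyrrolidin-1-yl on a carbonyl carbon. Going by the values given here, only the step of a 3.4-fold higher number from compound 1 to compound 2 (0.53 log units; beyond the scatter) bears on this change, and only in part: it shows that the carbamate end of the molecule is tolerant of variation, with the cyclic group giving the higher number and an open-chain amino group the lower one. Compound 3 returns to an open-chain amino group, albeit a longer one carrying an imidazole, so a modest move back toward the lower number is expected, giving a 2.2-fold lower number from compound 2 to compound 3 (0.35 log units; beyond the scatter). Compound 3 is accordingly estimated to show 4.5 nM in this assay, within a range from 1.5 nM to 14 nM.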

Compound 3, half-maximal effective concentration: 45.3 nM
For compound 3 the middle estimate is 10-fold (1.00 log units) below the measured one, outside the stated range (above it).
By their numbers in this assay, from the lowest: compound 1; then compound 2; then compound 3.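

In this assay the carbamate end proves less forgiving than the first pair suggested: the change from the cyclic group to the imidazole-bearing chain brings a 4.5-fold higher number from compound 2 to compound 3 (0.65 log units; beyond the scatter), and the change on the open chain brings a 15-fold higher number from compound 1 to compound 3 (1.18 log units; beyond the scatter), the largest step among these compounds. An open-chain amino group on the carbonyl carbon therefore does not by itself go with the lower number, as compound 1 and compound 3 both carry one yet stand at opposite ends of the order, with the 3-hydroxy-3-methylpyrrolidin-1-yl of compound 2 in the middle. Nothing available here explains why the (3-(1H-imidazol-1-yl)propyl)amino group goes with the highest number.

On these data alone, it remains open whether the imidazole ring itself or the length of the chain goes with the higher number, a question that a phenyl ring or a dimethylamino group at the end of the same propyl chain would address. Also open, as far as these compounds go, is where a morpholine or an unsubstituted pyrrolidine on the carbonyl carbon would fall relative to compound 2 .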